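Compound 3: piperazine replaced by pyridinylamino on the chain

The compounds below may be only part of what the source reports. "The series", "measured", "known", "first", "only" and "open" are said of these compounds alone.

Compound 2 `Cc1c(C)c2c(c(C)c1O)CCC(C)(CN1CCNCC1)O2` is measured in a functional assay (brain) for inhibition, with Rattus norvegicus as the target (on this read-out lower numbers stand for stronger inhibition and higher numbers for weaker inhibition), at 1000 nM, the highest of the two numbers in hand. Going by the values given here, compound 1 `COc1ccc(N2CCN(CC3(C)CCc4c(C)c(O)c(C)c(C)c4O3)CC2)cc1` gives 200 nM in this assay; the only known step, a 5.0-fold higher number from compound 1 to compound 2 (0.70 log units; beyond the scatter), consists of hydrogen in place of 4-methoxyphenyl on an amine nitrogen in a ring. Compound 3 `Cc1c(C)c2c(c(C)c1O)CCC(C)(CNc1ccncc1)O2` differs from compound 2 in one place: (pyridin-4-yl)amino in place of piperazin-1-yl on a saturated chain carbon bound to a saturated ring carbon. Among the compounds with values here, no measured step touches this exact exchange; the step from compound 1 to compound 2 bears on it only in that an aromatic ring on the chain-borne nitrogen is again present in compound 3, where compound 2 lacks one. The expected outcome for compound 3 is therefore a modest move toward a lower number, with wide uncertainty, as a 1.7-fold lower number from compound 2 to compound 3 (0.22 log units; within the scatter). For compound 3 the estimate in this assay is 600 nM, within a range from 150 nM to 2500 nM.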

Compound 3, half-maximal inhibitory concentration: 16000 nM
The estimate for compound 3 lay 27-fold (1.43 log units) below the measured number, and the stated range ends below it.
By their numbers in this assay, from the lowest: compound 1; then compound 2; then compound 3.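

In this assay, replacing piperazin-1-yl with (pyridin-4-yl)amino on a saturated chain carbon bound to a saturated ring carbon gives a 16-fold higher number from compound 2 to compound 3 (1.20 log units; beyond the scatter), so this position does not tolerate every nitrogen-bearing group with a similar count of heavy atoms. The earlier step, a 5.0-fold higher number from compound 1 to compound 2 (0.70 log units; beyond the scatter), tied the 4-methoxyphenyl group on the piperazine to the lower number, but compound 3 goes against any general reading of that step: an aromatic ring on the nitrogen does not by itself bring a lower number. Nothing available explains why this exchange weakens inhibition.

The compounds shown cannot separate the loss of the piperazine ring from the arrival of the pyridine ring. A phenylamino group at this place, or a piperazine carrying pyridin-4-yl, would help to tell these two parts of the change apart.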